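The compounds below may be only part of what the source reports. "The series", "measured", "known", "first", "only" and "open" are said of these compounds alone.

In an ADME assay on HEK293 cells (Homo sapiens) for cytotoxicity (on this read-out lower numbers stand for stronger inhibition and higher numbers for weaker inhibition), compound 1 (`CCCCCCCCCCCCCCNC(=O)[C@H](CO)/N=C/c1ccccc1OC`) gives 79200 nM while compound 2 (`CCCCCCCCCCCCCCNC(=O)[C@H](CO)/N=C/c1cccc(Cl)c1`) gives 77000 nM and compound 3 (`CCCCCCCCCCCCCCNC(=O)[C@H](CO)/N=C/c1ccc(C)cc1`) gives 47300 nM on the same shared core. Compound 3 thus stands within the scatter of both others. Compound 4 (`CCCCCCCCCCCCCCNC(=O)[C@H](CO)/N=C/c1ccccc1C`) differs from compound 3 by 2-methylphenyl in place of 4-methylphenyl on a carbon with a double bond to nitrogen with 2-methylphenyl in place of 4-methylphenyl on a carbon with a double bond to nitrogen. Three measured swaps at that carbon bear on this change: a 1.0-fold lower number from compound 1 to compound 2 (0.01 log units; within the scatter) and a 1.7-fold lower number from compound 1 to compound 3 (0.22 log units; within the scatter) and a 1.6-fold lower number from compound 2 to compound 3 (0.21 log units; within the scatter) all stay within the scatter. In this assay the change is therefore expected to give no step beyond the scatter, with a 1.3-fold higher number from compound 3 to compound 4 (0.10 log units; within the scatter) as the estimated step. Compound 4 is estimated at 60000 nM with an expected range from 35000 nM to 100000 nM for repeat measurements.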

Compound 4, half-maximal inhibitory concentration: 81100 nM
Beside the measured number, compound 4's estimate is 1.4-fold (0.13 log units) below it; low and high end bracket the measured number.
By their numbers in this assay, from the lowest: compounds 3, 2, 1 and 4 (each within the scatter of the next).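

Moving the methyl group alone, with the same atoms joined differently, gives a 1.7-fold higher number from compound 3 to compound 4 (0.23 log units; within the scatter) in this assay, so this isomer change at the carbon with a double bond to nitrogen stays within the scatter. The swap for the chloro compound gives a 1.1-fold higher number from compound 2 to compound 4 (0.02 log units; within the scatter), and methyl in place of methoxy on an aromatic carbon gives a 1.0-fold higher number from compound 1 to compound 4 (0.01 log units; within the scatter), so neither step leaves the scatter either. Nothing available explains these small steps. From the compounds shown here alone, whether an amine or a carboxylic acid on the aromatic ring, or a shorter chain, would move the number beyond the scatter stays open.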